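A few compounds are considered here, and "the series" means these few. Any claim that something is new, unique, unknown or untested is made for them only; others in the source may bear on it.

Series notes. Compound 2 `CN1CCN(c2ccc3nc(-c4cccc(-c5ccsc5)c4)c(-c4ccncc4)n3n2)CC1` shares its core with compound 1 `CN1CCN(c2ccc3nc(-c4cccc(-c5ccccc5)c4)c(-c4ccncc4)n3n2)CC1` and compound 3 `CN1CCN(c2ccc3nc(-c4ccc5ncsc5c4)c(-c4ccncc4)n3n2)CC1`. In an ADME assay on HFF cells (Homo sapiens) for cytotoxicity, read by resazurin assay, with a stated time of 96 h (on this read-out higher numbers stand for lower toxicity in this test and lower numbers for higher toxicity in this test), compound 2 gives 6300 nM, the lowest of the three numbers, although compound 1, which gives 10900 nM, sits within the scatter of it; compound 3 gives 17500 nM. The measured steps are a 1.7-fold lower number from compound 1 to compound 2 (0.24 log units; within the scatter) and a 2.8-fold higher number from compound 2 to compound 3 (0.44 log units; beyond the scatter). Compound 4 `CN1CCN(c2ccc3nc(-c4cccc5c4OCCO5)c(-c4ccncc4)n3n2)CC1` differs from compound 2 in one place: 2,3-dihydro-1,4-benzodioxin-5-yl in place of 3-(thiophen-3-yl)phenyl on an aromatic carbon. The step to compound 3 also replaced 3-(thiophen-3-yl)phenyl and bears most on this change; the step from compound 1 stays within the scatter. A modest rise in this assay is therefore expected, about a 1.9-fold higher number from compound 2 to compound 4 (0.28 log units; within the scatter). Compound 4 is estimated at 12000 nM, with a range of 5000 nM to 28000 nM.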

Compound 4, half-maximal cytotoxic concentration: > 50000 nM
Compound 4: only a limit was reported; the forecaster's own chance of this, stated with the estimate: 10%; middle value at least 4.1-fold (0.61 log units) away from the limit.
By their numbers in this assay, from the lowest: compounds 2, 1 and 3 (each within the scatter of the next, the first and the last beyond it). At a limit, above all of these: compound 4.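

The value of compound 4 in this assay is a limit: the limit of > 50000 nM in this assay, at which 1 of the 4 values shown sits.

At this aromatic carbon, 2,3-dihydro-1,4-benzodioxin-5-yl gives an at least 7.9-fold higher number from compound 2 to compound 4 (0.89 log units; beyond the scatter) and an at least 2.8-fold higher number from compound 3 to compound 4 (0.45 log units; beyond the scatter), so the read-out here moves beyond the scatter against both groups it is compared with. The earlier compounds carried only aromatic rings at this place, and compound 4 is the first shown with a six-membered non-aromatic ring holding two oxygens.

The compounds shown do not separate the part played by the two oxygens from that of the non-aromatic ring. An open-chain dimethoxyphenyl group at this place could separate them.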